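Swapping Chloro for Nitro: What to Expect from Compound 4

This account rests on a few compounds, and the source may have more. Where it says the series, first, only, none or still open, it means among the compounds named here.

Compound 1 `COc1ccc(-c2nc3cc(Cl)ccc3[nH]2)c(F)c1` and compound 2 `COc1ccc(Br)c(-c2nc3cc(Cl)ccc3[nH]2)c1O` share a core; the difference between the two cores is not broken down here. In an assay for inhibition of Alpha amylase (Homo sapiens), with a stated time of 10 min (a higher number here means a weaker inhibitor, a lower number a stronger inhibitor), compound 1 gives 2740 nM, and compound 2 gives 2210 nM. Compound 3 `COc1ccc(-c2nc3cc([N+](=O)[O-])ccc3[nH]2)c(F)c1` differs from compound 1 by a single change: nitro in place of chloro on an aromatic carbon. In this assay compound 3 gives 2750 nM, so that a 1.0-fold higher number from compound 1 to compound 3 (0.00 log units; within the scatter). Compound 4 `COc1ccc(Br)c(-c2nc3cc([N+](=O)[O-])ccc3[nH]2)c1O` stands to compound 2 exactly as compound 3 stands to compound 1, with the same change at the same place: nitro in place of chloro on an aromatic carbon. Because the earlier step of a 1.0-fold higher number from compound 1 to compound 3 (0.00 log units; within the scatter) lay within the scatter, the expected step in this assay is a 1.0-fold lower number from compound 2 to compound 4 (0.00 log units; within the scatter). The estimate for compound 4 in this assay is therefore 2200 nM, with a likely range from 1100 nM to 4400 nM.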

Compound 4, half-maximal inhibitory concentration: 2290 nM
The estimate for compound 4 lay 1.0-fold (0.02 log units) below the measured number; the measured number falls inside the stated range.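

In this assay the swap of chloro for nitro gives a 1.0-fold higher number from compound 2 to compound 4 (0.02 log units; within the scatter) and so matches the earlier step on the core of compound 1: the same change on two cores in this assay, a 1.0-fold higher number (0.00 log units; within the scatter) from compound 1 to compound 3 and a 1.0-fold higher number (0.02 log units; within the scatter) from compound 2 to compound 4, 1.0-fold (0.01 log units) apart, within the scatter of two such steps. Across these two cores, the change carries over as a step within the scatter, with no difference between the cores that the data can separate. This rests on two pairs only: it does not show that the same would hold on any other core, and it does not explain why the number does not move.

The compounds shown carry only chloro or nitro at this place. From the compounds shown here alone, whether an amine or a carboxylic acid there would also leave the number within the scatter remains open.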